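This account rests on a few compounds, and the source may have more. Where it says the series, first, only, none or still open, it means among the compounds named here.

In a functional assay on HepG2 cells (Homo sapiens) for antiproliferative activity, read by MTT assay, with a stated time of 48 h (a lower number here means a stronger inhibitor, a higher number a weaker inhibitor), compound 1 `CC(=O)N1N=C(c2ccc3ccccc3c2)OC1c1ccccc1Cl` gives 4.32 ug/mL, compound 2 `CC(=O)N1N=C(c2ccc3ccccc3c2)OC1c1ccc(Cl)cc1` gives 1.88 ug/mL and compound 3 `CC(=O)N1N=C(c2ccc3ccccc3c2)OC1c1ccc([N+](=O)[O-])cc1` gives 8.1 ug/mL. Compound 3 sits within the scatter of compound 1, as a 1.9-fold higher number from compound 1 to compound 3 (0.27 log units; within the scatter) shows, while a 4.3-fold higher number from compound 2 to compound 3 (0.63 log units; beyond the scatter) lies beyond it. Compound 4 `CC(=O)N1N=C(c2ccc3ccccc3c2)OC1c1ccc(C)cc1` brings methyl in place of nitro on an aromatic carbon. Among the compounds with values here, no measured compound carries methyl, so the closest guide is the modest step of a 4.3-fold higher number from compound 2 to compound 3 (0.63 log units; beyond the scatter), which exchanged chloro for nitro at that carbon. The step of a 2.3-fold lower number from compound 1 to compound 2 (0.36 log units; beyond the scatter) is also modest. The expected change is likewise modest, towards a lower number in this assay: a 2.3-fold lower number from compound 3 to compound 4 (0.36 log units; beyond the scatter). Compound 4 is estimated at 3.5 ug/mL, with a range from 1.5 ug/mL to 8.5 ug/mL.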

Compound 4, half-maximal inhibitory concentration: 2.26 ug/mL
Compound 4: middle estimate off by 1.5-fold (0.19 log units), on the high side, and the stated range covers the measured number.
By their numbers in this assay, from the lowest: compounds 2, 4, 1 and 3 (each within the scatter of the next, the first and the last beyond it).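

In this assay, methyl at this aromatic carbon cannot be told apart from chloro, with a 1.2-fold higher number from compound 2 to compound 4 (0.08 log units; within the scatter), whereas replacing nitro gives a 3.6-fold lower number from compound 3 to compound 4 (0.55 log units; beyond the scatter), so of these three groups on the shared core, only nitro stands apart from both others. The 4-methylphenyl group also cannot be separated from 2-chlorophenyl, as a 1.9-fold lower number from compound 1 to compound 4 (0.28 log units; within the scatter) shows. No measurement given here accounts for the separate standing of nitro. From the compounds shown here alone, whether an amine or a methoxy group at this carbon would stay with methyl and chloro or fall with nitro remains open. So does the outcome for a longer chain such as ethyl.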